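Swapping Bromo for Isopropyl: Expected Cytotoxicity Outcome

The compounds below may be only part of what the source reports. "The series", "measured", "known", "first", "only" and "open" are said of these compounds alone.

Of the compounds shown here, three sharing one core have been tested in an ADME assay on HEL cells (Homo sapiens) for cytotoxicity, read by microscopy (on this read-out higher numbers stand for lower toxicity in this test and lower numbers for higher toxicity in this test), which records how much compound the cells tolerate before damage appears under the microscope. Compound 1 `O=c1ccn(CCCCCOc2ccc(Br)cc2)c(=O)[nH]1` gives 100000 nM in this assay, the highest of the two plain numbers. Compound 2 `O=c1ccn(CCCCCCOc2ccc(Br)cc2)c(=O)[nH]1` gives 20000 nM, a lower number and so more toxic in this test, with a gap from compound 1 that lies beyond the usual scatter. Compound 3 `O=c1ccn(CCCOc2ccc(Br)cc2)c(=O)[nH]1` gives > 100000 nM, which is a limit of the assay and not a measurement. Its read-out stopped at the limit of > 100000 nM in this assay, at which 1 of the 3 values shown sits.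

Compound 4 `CC(C)c1ccc(OCCCCCn2ccc(=O)[nH]c2=O)cc1` has not yet been measured. It differs from compound 1 by isopropyl in place of bromo on an aromatic carbon. For the measured compounds named here, no measured pair in this set shows such a swap, so its size must be guessed rather than read. Both groups carry no hydrogen-bond donors and no acceptors, and the expected step of a 1.3-fold lower number from compound 1 to compound 4 (0.10 log units; within the scatter) is none beyond the scatter. Compound 4 is therefore estimated at 80000 nM, within a range of 25000 nM to 200000 nM.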

Compound 4, minimum cytotoxic concentration: 100000 nM
Compound 4: the middle estimate sits 1.3-fold (0.10 log units) below what was measured; the range from low to high includes it.
By their numbers in this assay, from the lowest: compound 2; then compounds 1 and 4 (each within the scatter of the next).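

Compounds 1, 2 and 3 all carry bromo, so they could say nothing about this position on the aromatic ring. Exchanging bromo, with 1 heavy atom, for isopropyl, with 3 heavy atoms, gives no change at the digits printed from compound 1 to compound 4 (within the scatter) in this assay, so on this evidence the position accepts either group without a visible shift in toxicity. Both compounds stand at the top of the readable range, however, so a further drop in toxicity could hardly show here: the limit of > 100000 nM in this assay, at which 1 of the 4 values shown sits.

From the compounds shown here alone, what an amine or a carboxylic acid would do at this position remains open. Also open, going by these compounds, is whether isopropyl would leave the number unchanged on the longer chain of compound 2, which gives 20000 nM and so has room for movement in either direction.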